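The source may hold more compounds than are shown below. What is called first, only, known or untested is meant among the compounds shown, and "the series" means these compounds.

Of the compounds shown here, three have so far been measured in an ADME assay on the whole organism for inhibition, with Triticum aestivum as the target, with a stated time of 5 days; a higher number here means a weaker inhibitor, a lower number a stronger inhibitor. Compound 1 `CCC1Oc2c(Cl)cccc2N(O)C1=O` gives 345000 nM, compound 2 `CCC1Oc2ccc(Cl)cc2N(O)C1=O` gives 130000 nM, and compound 3 `CCC(=O)ON1C(=O)COc2ccc(F)cc21` gives 81900 nM. Among these three numbers compound 2 holds the second highest; its value and that of compound 3 lie within the scatter of each other, while compound 1 sits beyond the scatter at a higher number. Compound 4 `CCCC1Oc2ccc(Cl)cc2N(O)C1=O` differs from compound 2 by methyl in place of hydrogen on a saturated chain carbon, two bonds along the chain from a saturated ring carbon. Among the measured compounds shown here, no pair of measured compounds shows this change, so the expectation rests on the change itself: any step in this assay is expected to stay within the scatter, in either direction. Compound 4 is therefore estimated at 100000 nM, between 40000 nM and 300000 nM. The step of a 1.3-fold lower number from compound 2 to compound 4 (0.11 log units; within the scatter) is expected to be small.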

Compound 4, half-maximal inhibitory concentration: 470000 nM
Compound 4: the middle estimate sits 4.7-fold (0.67 log units) below what was measured; measured number above the stated range.
By their numbers in this assay, from the lowest: compounds 3 and 2 (each within the scatter of the next); then compounds 1 and 4 (each within the scatter of the next).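

In this assay, among the compounds shown here, this is the first comparison of compounds differing in one place, and it shows that the chain position is not indifferent to change. Lengthening ethyl to propyl, with methyl in place of hydrogen on the saturated chain carbon, gives a 3.6-fold higher number from compound 2 to compound 4 (0.56 log units; beyond the scatter), a modest weakening of inhibition. Nothing measured here bears on why the number rises. From the compounds shown here alone, whether a longer chain would weaken inhibition further remains open. So does whether an amine or a carboxylic acid on this chain would behave like methyl.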